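This account rests on a few compounds, and the source may have more. Where it says the series, first, only, none or still open, it means among the compounds named here.

Measured so far:
- compound 1 `COc1ccc(C(=O)Nc2ccccc2Cl)cc1OC1CCCC1`: in an assay on isolated protein for inhibition of phosphodiesterase 4A (Sus scrofa) (on this read-out lower numbers stand for stronger inhibition and higher numbers for weaker inhibition), compound 1 gives 190 nM.
- compound 2 `COc1ccc(C(=O)Nc2cccc(Cl)c2Cl)cc1OC1CCCC1`: in this assay compound 2 gives > 200000 nM, which is a limit of the assay and not a number.

Compound 2 therefore stands only at a limit; the relevant observation is the limit of > 200000 nM in this assay, at which 1 of the 2 values shown sits. Among the measured compounds shown here, the one measured step, an at least 1000-fold higher number from compound 1 to compound 2 (3.02 log units; beyond the scatter), goes from the number of compound 1 to that limit.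

Compound 3 `COc1ccc(C(=O)Nc2c(F)cccc2Cl)cc1OC1CCCC1` has not been measured in this assay. It differs from compound 2 by 2-chloro-6-fluorophenyl in place of 2,3-dichlorophenyl on an amide-type nitrogen. The measured step bears on it only in reverse: the chloro that entered on an aromatic carbon in an at least 1000-fold higher number from compound 1 to compound 2 (3.02 log units; beyond the scatter) is taken out again, while the 2-chloro-6-fluorophenyl brings in fluorine in its place. Since the starting point is a limit, a large step down in the number is expected, an at least 500-fold lower number from compound 2 to compound 3 (2.69 log units; beyond the scatter), landing compound 3 nearer compound 1 than compound 2. For compound 3 the estimate is 400 nM, with a range of 60 nM to 5000 nM.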

Compound 3, half-maximal inhibitory concentration: 240 nM
Estimate against measurement, compound 3: 1.7-fold (0.22 log units) above, within the range that was stated.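

In this assay, 2-chloro-6-fluorophenyl in place of 2,3-dichlorophenyl on the amide-type nitrogen gives an at least 830-fold lower number from compound 2 to compound 3 (2.92 log units; beyond the scatter), so this aromatic group can carry a second halogen without the loss seen for compound 2. The added fluoro gives a 1.3-fold higher number from compound 1 to compound 3 (0.10 log units; within the scatter), which leaves compound 1 and compound 3 level within the scatter. Compound 2 stands at a limit and not a number, so the step from it gives only a bound on the size of the change: the limit of > 200000 nM in this assay, at which 1 of the 3 values shown sits.

Compound 2 and compound 3 differ both in the added halogen and in where it sits on the ring, so the series does not yet separate these two changes. On these data alone, whether a methyl, a methoxy or a nitrile on the ring would follow compound 2 or compound 3 also remains open.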